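Putting carbamoyl in place of (methylamino)methyl

The source may report more compounds than this note shows. Statements on the series, on what has been measured and on what is new or still open speak of the compounds shown alone.

In an ADME assay on HEp-2 cells (Homo sapiens) for cytotoxicity (on this read-out higher numbers stand for lower toxicity in this test and lower numbers for higher toxicity in this test), compound 1 (`CC(C)CCn1c(Cn2c(=O)n(CC(=O)OC(C)(C)C)c3ccccc32)nc2cc(/C(N)=N\O)ccc21`) gives 19800 nM and compound 2 (`CC(C)CCn1c(Cn2c(=O)n(C(C)C)c3ccccc32)nc2ccc(C#N)cc21`) gives 10000 nM on the same scale. Compound 3 (`CNCc1ccc2nc(Cn3c(=O)n(C(C)C)c4ccccc43)n(CCC(C)C)c2c1`) gives 4810 nM as the lowest of these three numbers. Compound 4 (`CC(C)CCn1c(Cn2c(=O)n(C(C)C)c3ccccc32)nc2ccc(C(N)=O)cc21`) carries carbamoyl in place of (methylamino)methyl on an aromatic carbon. Among the compounds with values here, one measured step bears on this change: a 2.1-fold lower number from compound 2 to compound 3 (0.32 log units; beyond the scatter) with (methylamino)methyl in place of cyano. Within the data shown here, no measured compound carries carbamoyl, so that modest step is only a loose guide. A modest rise is expected, with the estimated step being a 2.1-fold higher number from compound 3 to compound 4 (0.32 log units; beyond the scatter) in this assay for this swap. For compound 4 the estimated value is 10000 nM within an expected range from 4500 nM to 25000 nM in this test.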

Compound 4, half-maximal cytotoxic concentration: 49900 nM
The estimate for compound 4 lay 5.0-fold (0.70 log units) below the measured number, and the stated range ends below it.
By their numbers in this assay, from the lowest: compound 3; then compounds 2 and 1 (each within the scatter of the next); then compound 4.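

Swapping between groups at this aromatic carbon can shift the result strongly: in this assay carbamoyl gives a 10-fold higher number from compound 3 to compound 4 (1.02 log units; beyond the scatter) even though the group leaving and the group entering have the same count of heavy atoms and neither has a net charge. Replacing the nitrile with carbamoyl gives a 5.0-fold higher number from compound 2 to compound 4 (0.70 log units; beyond the scatter) and so leaves carbamoyl with the highest number, meaning the lowest toxicity in this test, of the three groups seen here. Nothing measured here explains this rise.

On these data alone, whether a carboxylic acid or a methyl ester at this position would stay as high as carbamoyl remains open.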